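Nitrooxy-acyl group on the ring nitrogen of compound 1

This account rests on a few compounds, and the source may have more. Where it says the series, first, only, none or still open, it means among the compounds named here.

Measured so far:
- compound 1, `COc1ccc(C2=NNC(c3c(Cl)cccc3Cl)C2)cc1OC`: 26%
- compound 2, `COc1ccc(C2=NNC(c3c(Cl)cccc3Cl)C2)cc1`: 54%
- compound 3, `COc1ccc(C2CC(c3ccc(OC)c(OC)c3)=NN2C(=O)CO[N+](=O)[O-])c(OC)c1`: 38%

In a functional assay on the whole organism (strain albino) for inhibition, with Rattus norvegicus as the target, read by paw edema, with stated times of 30 min and 1 h, at a dose of 100 mg/kg by the oral route (a higher number here means more inhibition at the dose given (going by the name of the read-out), a lower number less inhibition), compound 1 gives 26%, the lowest of the three numbers. Its nearest neighbour is compound 3, which gives 38%, a gap beyond the scatter; compound 2 stands furthest away, and the step of a number 28 percentage points higher from compound 1 to compound 2 (beyond the scatter) came from hydrogen in place of methoxy on an aromatic carbon.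

Compound 4, `COc1ccc(C2=NN(C(=O)C(C)O[N+](=O)[O-])C(c3c(Cl)cccc3Cl)C2)cc1OC`, differs from compound 1 in a different way: a group of 8 heavy atoms (3 carbon, 1 nitrogen, 4 oxygen; no ring) in place of a hydrogen atom, on an amine nitrogen in a ring. Among the compounds with values here, no measured step concerns this kind of change; the one step on record, from compound 1 to compound 2, alters an aromatic methoxy and does not bear on the ring nitrogen. Within the data shown here, the only hint comes from compound 3, whose ring nitrogen is also substituted rather than bearing hydrogen, and which sits somewhat above compound 1; but compound 3 also differs in both aromatic rings, so the comparison is loose.

Compound 4 is therefore expected to give 35%, within a range of 20% to 50%, a step of a number 9 percentage points higher from compound 1 to compound 4 (within the scatter) that is estimated to be small and uncertain in direction.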

Compound 4, a percentage reported as inhibition, in the whole organism at one dose (the size of the read-out at that dose, not a potency): 47%
Beside the measured number, compound 4's estimate is 12 percentage points below it; low and high end bracket the measured number.
By their numbers in this assay, from the lowest: compound 1; then compounds 3, 4 and 2 (each within the scatter of the next, the first and the last beyond it).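

In this assay the hydrogen on the amine nitrogen in the ring turns out not to be required: the group of 8 heavy atoms can stand in its place, with a number 21 percentage points higher from compound 1 to compound 4 (beyond the scatter) at this single dose. Within the data shown here, this is the first measured change at this position, as the earlier step concerned only a methoxy on an aromatic carbon, so the ring nitrogen is now a second place on compound 1 where one change moves the number beyond the scatter. No measurement at hand explains the rise.

On these data alone, whether the whole group is needed stays open: a plain acetyl group on the same nitrogen, or a longer chain ending in a carboxylic acid, would show whether the carbonyl part alone goes with the higher number or whether the nitrogen-bearing end of the group also matters. Equally open, as far as these compounds go, is whether the same group on the ring nitrogen of compound 2, which carries hydrogen in place of the methoxy, would change the number in the same direction.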